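Half-life notes on a small acrylamide-type anilide series

The source may report more compounds than this note shows. Statements on the series, on what has been measured and on what is new or still open speak of the compounds shown alone.

Compound 1 `C=C(Cc1ccccc1)C(=O)Nc1ccccc1` and compound 2 `CN(C)CC/C=C/C(=O)Nc1ccccc1` share the anilide core and differ in the unsaturated chain carried on the carbonyl. In an ADME assay for pharmacokinetics, read by LC-MS, in phosphate buffer, with a stated time of 120 min, at pH 7.4, tested at 1 uM, in the presence of a further agent that is not named here (a lower number here means that the compound disappears faster, a higher number that the compound lasts longer), compound 1 is reported only as a limit of the assay, > 8.53 h, and not as a number. In this assay compound 2 gives 7.38 h, the only plain number shown in the set. The remaining value, that of compound 1, is a limit (the limit of > 8.53 h in this assay, at which 1 of the 2 values shown sits). Going by the values given here, no step between two measured compounds is available, so the two values show only that compound 2 sits near the upper edge of what the assay resolves.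

Compound 3 `O=C(/C=C/CF)Nc1ccccc1` differs from compound 2 as follows: fluoro in place of (dimethylamino)methyl on a saturated chain carbon bound to a double-bonded chain carbon. The expected step from compound 2 to compound 3 in this assay is a 1.1-fold higher number from compound 2 to compound 3 (0.04 log units; within the scatter), of a size not beyond the scatter of repeated measurements in either direction. For compound 3 the estimate in this assay is 8 h, with a range from 3 h to 20 h.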

Compound 3, half-life: > 8.53 h
Compound 3 was reported as a limit; the forecaster's own chance of this, stated with the estimate: 40%; middle value at least 1.0-fold (0.02 log units) from the limit.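

In this assay, going by these compounds alone, the change on a saturated chain carbon bound to a double-bonded chain carbon gives the first readable step: an at least 1.1-fold higher number from compound 2 to compound 3 (0.06 log units; that floor lies within the scatter). Compound 3 stands as a limit of the assay and not as a number: the limit of > 8.53 h in this assay, at which 2 of the 3 values shown sit. As far as these compounds go, the half-life therefore does not fall measurably when fluoro takes the place of (dimethylamino)methyl at this position, so the amine is not required to keep this read-out at the top of the resolved range, though the true size of the step remains unknown.

With compound 3 at the limit, the series does not yet show how far this position can be changed before the half-life drops into the measurable range. From the compounds shown here alone, a hydroxyl, a carboxylic acid, a primary amine or a longer chain at this carbon remains open, as does any change on the shared core.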